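Replacing a Fluoro Group with a Benzyloxy Ether

A few compounds are considered here, and "the series" means these few. Any claim that something is new, unique, unknown or untested is made for them only; others in the source may bear on it.

Compound 1 `CS(=O)(=O)CCNc1nc(-c2ccc3ncnc(Nc4ccc5c(cnn5Cc5ccccc5)c4)c3c2)cs1`: 12000 nM
Compound 2 `CS(=O)(=O)CCNc1nc(-c2ccc3ncnc(Nc4ccc(F)c(Cl)c4)c3c2)cs1`: > 10000 nM

Compound 1 `CS(=O)(=O)CCNc1nc(-c2ccc3ncnc(Nc4ccc5c(cnn5Cc5ccccc5)c4)c3c2)cs1` was tested in a functional assay on HFF cells (Homo sapiens) for inhibition (a higher number here means a weaker inhibitor, a lower number a stronger inhibitor), and gave 12000 nM. Compound 2 `CS(=O)(=O)CCNc1nc(-c2ccc3ncnc(Nc4ccc(F)c(Cl)c4)c3c2)cs1` was tested in the same assay, but for compound 2 the reading of > 10000 nM is a limit of the assay and not a number. Among the two values shown, one sits at the limit of > 10000 nM in this assay, at which 1 of the 2 values shown sits, so compound 2 stands at the weak end of what this assay reports, with no exact figure to place it against compound 1.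

Compound 3 `CS(=O)(=O)CCNc1nc(-c2ccc3ncnc(Nc4ccc(OCc5cccc(F)c5)c(Cl)c4)c3c2)cs1` differs from compound 2 in one place: (3-fluorobenzyl)oxy in place of fluoro on an aromatic carbon, on an aromatic carbon that is ortho to a chloro group and para to a large group. No step between measured compounds is shown, so the size of this change cannot be read from data. The expected step from compound 2 to compound 3 is an at least 1.2-fold lower number from compound 2 to compound 3 (0.09 log units; that floor lies within the scatter), a modest gain that may not exceed the scatter. For compound 3 the expected value in this assay is 8000 nM, within a range of 2000 nM to 30000 nM.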

Compound 3, half-maximal inhibitory concentration: > 23000 nM
Compound 3 gave a limit, no number (the forecaster's own chance of this, stated with the estimate: 40%); middle value at least 2.8-fold (0.45 log units) from the limit.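

For the compounds shown here, compound 2 and compound 3 both read as limits, not numbers, in this assay, so no step between them can be read. The compounds shown leave open whether (3-fluorobenzyl)oxy in place of fluoro changes inhibition at all, and in which direction.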